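Lengthening the chain from compound 3 to compound 4

The compounds below may be only part of what the source reports. "The series", "measured", "known", "first", "only" and "open" are said of these compounds alone.

Measured in a functional assay on HT-29 cells (Homo sapiens) for inhibition, read by sulforhodamine B assay, with a stated time of 72 h; on this read-out higher numbers stand for weaker inhibition and lower numbers for stronger inhibition:
- compound 1 `COc1cc2c(Nc3ccc(F)c(Cl)c3)ncnc2cc1OCCCn1ccnc1[N+](=O)[O-]`: 6140 nM
- compound 2 `C#Cc1cccc(Nc2ncnc3cc(OCCOCCn4ccnc4[N+](=O)[O-])c(OC)cc23)c1`: 8770 nM
- compound 3 `COc1cc2c(Nc3ccc(OCc4cccc(F)c4)c(Cl)c3)ncnc2cc1OCCCn1ccnc1[N+](=O)[O-]`: 3790 nM

Compound 3 at 3790 nM lies within the scatter of compound 1, while the number for compound 2 is higher, beyond the scatter.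

Compound 4 `COc1cc2c(Nc3ccc(OCc4cccc(F)c4)c(Cl)c3)ncnc2cc1OCCCCCn1ccnc1[N+](=O)[O-]` is compound 3 with one change: 2-(2-nitro-1H-imidazol-1-yl)ethyl in place of 2-nitro-1H-imidazol-1-yl on a saturated chain carbon, three bonds along the chain from an oxygen on an aromatic ring. The change lies on a saturated chain carbon, three bonds along the chain from an oxygen on an aromatic ring.

Among the compounds with values here, only one measured step is available, a 1.6-fold lower number from compound 1 to compound 3 (0.21 log units; within the scatter). It replaces fluoro on an aromatic carbon, leaves the chain untouched and stays within the scatter. Within the data shown here, compound 2 differs from the others in more than one place, so it gives no single-change step. Among the measured compounds shown here, no measured step isolates the chain, so the data offer little guidance, and no shift beyond the scatter is expected in this assay.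

The expected change is a 1.0-fold higher number from compound 3 to compound 4 (0.00 log units; within the scatter). For compound 4 the estimate is 3800 nM, with an expected range of 1700 nM to 8500 nM.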

Compound 4, half-maximal inhibitory concentration: 14100 nM
Beside the measured number, compound 4's estimate is 3.7-fold (0.57 log units) below it; the whole stated range lies below it.
By their numbers in this assay, from the lowest: compounds 3, 1, 2 and 4 (each within the scatter of the next, the first and the last beyond it).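

In this assay, within the data shown here, lengthening the chain gives a 3.7-fold higher number from compound 3 to compound 4 (0.57 log units; beyond the scatter), the first single-change step beyond the scatter and the first to alter the chain. The earlier step, a 1.6-fold lower number from compound 1 to compound 3 (0.21 log units; within the scatter), replaced fluoro on an aromatic carbon and stayed within the scatter, so it said nothing about this saturated chain carbon; the number here does respond to 2-(2-nitro-1H-imidazol-1-yl)ethyl in place of 2-nitro-1H-imidazol-1-yl. No measurement available bears on the reason for this rise.

On these data alone, the chain comparison rests on a single pair, so the effect of a shorter chain, or of an amine in place of 2-nitro-1H-imidazol-1-yl, remains open. Also open, as far as these compounds go, is whether the same lengthening gives a similar step on compound 1, which carries fluoro.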